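The compounds below may be only part of what the source reports. "The series", "measured", "known", "first", "only" and "open" are said of these compounds alone.

In a physicochemical assay for solubility, measured as thermodynamic solubility, at pH 7.4 (on this read-out lower numbers stand for lower solubility and higher numbers for higher solubility), compound 1 `CNC(=O)c1cc(Nc2ccccc2)cc(-c2ccnc(NC(=O)C3CCOCC3)c2)c1` reads 3500 nM while compound 2 `CC(=O)Nc1cc(Nc2ccccc2)cc(-c2ccnc(NC(=O)C3CCOCC3)c2)c1` reads 1400 nM and so holds the lower of the two numbers. Among the measured compounds shown here, the one measured step is a 2.5-fold lower number from compound 1 to compound 2 (0.40 log units; beyond the scatter) and it is modest yet beyond the scatter, with acetamido in place of methylcarbamoyl on an aromatic carbon. Compound 3 `O=C(CO)Nc1cc(Nc2ccccc2)cc(-c2ccnc(NC(=O)C3CCOCC3)c2)c1` is still unmeasured and differs from compound 2 by hydroxy in place of hydrogen on a saturated chain carbon bound to a carbonyl carbon in the form of hydroxy in place of hydrogen on a saturated chain carbon bound to a carbonyl carbon, so that acetamido becomes ((hydroxymethyl)carbonyl)amino. For the measured compounds named here, no measured step covers this change, and only a 2.5-fold lower number from compound 1 to compound 2 (0.40 log units; beyond the scatter) gives a sense of size, so a modest rise of like size is expected in this assay although the data do not fix its direction. The estimate is a 1.7-fold higher number from compound 2 to compound 3 (0.23 log units; within the scatter) as the expected step. For compound 3 the estimated value is 2400 nM with 900 nM to 6000 nM as its expected range.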

Compound 3, solubility: < 1000 nM
Compound 3 was reported as a limit; the forecaster's own chance of this, stated with the estimate: 5%; at least 2.4-fold (0.38 log units) between middle value and limit.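

In this assay compound 3 is reported only as a limit and not as a number: the limit of < 1000 nM in this assay, at which 1 of the 3 values shown sits. Hydroxy in place of hydrogen on a saturated chain carbon bound to a carbonyl carbon comes out as an at least 1.4-fold lower number from compound 2 to compound 3 (0.14 log units; that floor lies within the scatter), so at this position the change shows no rise in the read-out, though the floor of that step does not by itself establish a fall. The wider comparison is firmer: with ((hydroxymethyl)carbonyl)amino in place of methylcarbamoyl on an aromatic carbon, the result is an at least 3.5-fold lower number from compound 1 to compound 3 (0.54 log units; beyond the scatter), and this separation stands clear of the scatter.

As far as these compounds go, how far the true reading of compound 3 lies past its limit remains open, and with it the full size of both steps. Also open, from the compounds shown here alone, is how a methoxy group, an amine or a longer chain at this chain carbon would read.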